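The source may report more compounds than this note shows. Statements on the series, on what has been measured and on what is new or still open speak of the compounds shown alone.

Measured values in a functional assay on RPMI 8402 cells (Homo sapiens) for cytotoxicity; a lower number here means a stronger inhibitor, a higher number a weaker inhibitor:
Compound 1 `Cc1ccccc1-c1nc2cc(-c3nc4cc(C(N)=O)ccc4[nH]3)ccc2[nH]1` gives 8200 nM.
Compound 2 `Cc1ccc(-c2nc3cc(-c4nc5cc(C(N)=O)ccc5[nH]4)ccc3[nH]2)cc1` gives only a limit of the assay, > 25000 nM.
Compound 3 `NC(=O)c1ccc2[nH]c(-c3ccc4[nH]c(-c5cccc6ccccc56)nc4c3)nc2c1` gives 3700 nM.

Compound 2 sits at the limit of > 25000 nM in this assay, at which 1 of the 3 values shown sits. Its place in the series is therefore known only as a bound: the two measured steps that touch it, an at least 3.0-fold higher number from compound 1 to compound 2 (0.48 log units; beyond the scatter) and an at least 6.7-fold lower number from compound 2 to compound 3 (0.82 log units; beyond the scatter), are themselves only bounds, while a 2.2-fold lower number from compound 1 to compound 3 (0.35 log units; beyond the scatter) between the two compounds with full numbers is modest.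

Compound 4 `Cc1ccc(-c2nc3cc(-c4nc5cc(N6CCN(C)CC6)ccc5[nH]4)ccc3[nH]2)cc1` differs from compound 2 in one place: 4-methylpiperazin-1-yl in place of carbamoyl on an aromatic carbon. Among the measured compounds shown here, all three measured steps change the aryl group on the other end of the shared core; none of them alters the carbamoyl, so no measured step bears on this change. Compound 2 itself carries no number, only a limit, so neither the direction nor the size of the step in this assay can be taken from the measured steps.

For compound 4 a value around 15000 nM is expected, with a range from 3000 nM to 50000 nM, and the assay may again report only a limit. The step of an at least 1.6-fold lower number from compound 2 to compound 4 (0.22 log units; that floor lies within the scatter) is an estimate, not a measured change.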

Compound 4, half-maximal inhibitory concentration: 830 nM
Compound 4: middle estimate off by 18-fold (1.26 log units), on the high side; the measured number lies below the stated range.
By their numbers in this assay, from the lowest: compound 4; then compound 3; then compound 1. At a limit, above all of these: compound 2.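

Until compound 4, every measured step changed the aryl group on the other end of the shared core, and the carbamoyl stayed in place, so this position had not been tested in this assay. Replacing carbamoyl with 4-methylpiperazin-1-yl on this aromatic carbon gives an at least 30-fold lower number from compound 2 to compound 4 (1.47 log units; beyond the scatter), which shows that this position can move the number strongly even with the 4-methylphenyl group kept. That step is a floor and not a full size, because compound 2 is known only as a limit: the limit of > 25000 nM in this assay, at which 1 of the 4 values shown sits.

The compounds shown do not separate the contribution of the six-membered ring from that of its nitrogens, a question that morpholin-4-yl, a dimethylamino group or an open aminoethyl chain at the same place could address. Going by these compounds, it also remains open whether the ranking of the aryl groups, seen with carbamoyl in place, carries over when 4-methylpiperazin-1-yl is paired with 2-methylphenyl or naphthalen-1-yl.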